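The source may hold more compounds than are shown below. What is called first, only, known or untested is meant among the compounds shown, and "the series" means these compounds.

Working notes on the series. Compound 1 `c1cc(N2CCCCC2)nc(Nc2ccc(Oc3ncnc4sccc34)cc2)n1` has no single number in an assay on HEK293T cells for inhibition of nuclear factor NF-kappa-B complex (Homo sapiens), read by a luciferase reporter, with stated times of 6 h and 8 h; on this read-out lower numbers stand for stronger inhibition and higher numbers for weaker inhibition: its entry reads "not determined" (no result reported), and the same holds for compound 2 `c1ccc2c(c1)CCN(c1ccnc(Nc3ccc(Oc4ncnc5sccc45)cc3)n1)C2`, whose entry in this assay reads "not determined" (no result reported). Among the measured compounds shown here, the only number in the set comes from a structurally unrelated compound 3 `COc1ccc(C[C@H]2C(=O)N[C@@H](C)C(=O)N(C)[C@H]3Cc4cccc(c4)Oc4cc(ccc4O)C[C@H](C(=O)N[C@H](C)C(=O)N[C@@H](C)C(=O)N2C)N(C)C3=O)cc1`, which in this assay gives 65 nM. Compound 4 `CNC(=O)c1cc(Oc2ccc(Nc3nccc(N4CCCCC4)n3)cc2)ccn1` is not yet measured and differs from compound 1 as follows: a group of 10 heavy atoms (7 carbon, 2 nitrogen, 1 oxygen; one six-membered aromatic ring with 1 hetero atom) in place of a group of 9 heavy atoms (6 carbon, 2 nitrogen, 1 sulfur; one five-membered aromatic ring with 1 hetero atom, one six-membered aromatic ring with 2 hetero atoms), on an oxygen on an aromatic ring. For the measured compounds named here, no measured pair shares this change, so no step size can be anchored in this assay; the direction is open, and nothing here says whether the change moves the number beyond the scatter at all. Compound 4 is expected to give about 1500 nM in this assay, within a range of 200 nM to 10000 nM.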

Compound 4, half-maximal inhibitory concentration: 840 nM
Estimate against measurement, compound 4: 1.8-fold (0.25 log units) above; the measured number falls inside the stated range.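

Compound 4 gives 840 nM in this assay, but compound 1 has no single number there, so no step can be read between compound 1 and compound 4. As far as these compounds go, what the 2-(methylcarbamoyl)pyridin-4-yl group does to the number in this assay stays open, and no evidence at hand bears on the result.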